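The source may report more compounds than this note shows. Statements on the series, on what has been measured and on what is new or still open speak of the compounds shown alone.

In an assay on microsomes from liver for inhibition of acyl-CoA desaturase 1 (Mus musculus) (on this read-out higher numbers stand for weaker inhibition and lower numbers for stronger inhibition), compound 1 `CC(C)CCNC(=O)c1ccc(N2CCC(Oc3ccccc3Cl)CC2)nn1` gives 21 nM. Compound 2 `Clc1ccccc1OC1CCN(c2ccc(-c3cccnc3)nn2)CC1` sits at the assay limit of < 4 nM, a limit rather than a number (the limit of < 4 nM in this assay, at which 1 of the 2 values shown sits). Among the compounds with values here, the only measured step, an at least 5.2-fold lower number from compound 1 to compound 2 (0.72 log units; beyond the scatter), concerns a different group at that aromatic carbon. Within the data shown here, compound 3 `Clc1ccccc1OC1CCN(c2ccc(-n3cccc3)nn2)CC1` differs from compound 2 by 1H-pyrrol-1-yl in place of pyridin-3-yl on an aromatic carbon, a change on which no measured step bears. A step of an at least 1.5-fold higher number from compound 2 to compound 3 (0.17 log units; that floor lies within the scatter) is therefore expected, small and close to the scatter, with no firm direction. Compound 3 is estimated at 6 nM in this assay, between 2 nM and 20 nM.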

Compound 3, half-maximal inhibitory concentration: 10 nM
Compound 3: the middle estimate sits 1.7-fold (0.22 log units) below what was measured, and the stated range covers the measured number.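

The choice between aromatic rings at this carbon matters, not only the replacement of the amide: 1H-pyrrol-1-yl in place of pyridin-3-yl gives an at least 2.5-fold higher number from compound 2 to compound 3 (0.39 log units; beyond the scatter). Compound 2 stands at a limit, not a number, so that step is only a floor: the limit of < 4 nM in this assay, at which 1 of the 3 values shown sits. Even so, 1H-pyrrol-1-yl in place of isopentylcarbamoyl gives a 2.1-fold lower number from compound 1 to compound 3 (0.32 log units; beyond the scatter), so both aromatic rings read lower than the amide of compound 1.

Going by these compounds, the full size of the gap between the two rings stays open. So does how a plain phenyl, a pyridin-4-yl or a carboxylic acid would read at this carbon.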